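Bromophenyl triazole series: moving bromine to the 4-position

This account rests on a few compounds, and the source may have more. Where it says the series, first, only, none or still open, it means among the compounds named here.

Measured so far in a functional assay on OVCAR-3 cells (Homo sapiens) for inhibition, read by MTT assay, with a stated time of 24 h; a higher number here means a weaker inhibitor, a lower number a stronger inhibitor:
compound 1 `CC1(C)[C@H]2CC[C@]1(C)N(Cc1cn(-c3cccc(Cl)c3)nn1)C(=O)C2` gives 50 nM
compound 2 `COc1ccc(-n2cc(CN3C(=O)C[C@@H]4CC[C@@]3(C)C4(C)C)nn2)cc1` gives 250 nM
compound 3 `CC1(C)[C@H]2CC[C@]1(C)N(Cc1cn(-c3cccc(Br)c3)nn1)C(=O)C2` gives 30 nM

Compound 3 has the lowest number of the three, but its step from compound 1 is within the scatter: a 1.7-fold lower number from compound 1 to compound 3 (0.22 log units; within the scatter). Only compound 2 stands clearly apart; that step is an 8.3-fold lower number from compound 2 to compound 3 (0.92 log units; beyond the scatter), and the matching step from the chloro analogue is a 5.0-fold higher number from compound 1 to compound 2 (0.70 log units; beyond the scatter).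

Compound 4 `CC1(C)[C@H]2CC[C@]1(C)N(Cc1cn(-c3ccc(Br)cc3)nn1)C(=O)C2` is the next member. Its difference from compound 3:
4-bromophenyl in place of 3-bromophenyl on an aromatic nitrogen

Among the measured compounds shown here, no measured step moves a halogen between positions on this phenyl ring. The step from compound 1 to compound 3 shows that exchanging bromo for chloro at the same position stays within the scatter; the two steps to compound 2 show that the 4-methoxyphenyl compound gives a modestly higher number than either 3-halophenyl compound, though that comparison changes the group as well as its position. On this basis a small rise in the number, near the edge of the scatter, is expected for compound 4: a 2.3-fold higher number from compound 3 to compound 4 (0.37 log units; beyond the scatter). Compound 4 is estimated at 70 nM, with a range of 25 nM to 250 nM.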

Compound 4, half-maximal inhibitory concentration: 140 nM
Beside the measured number, compound 4's estimate is 2.0-fold (0.30 log units) below it, and the stated range covers the measured number.
By their numbers in this assay, from the lowest: compounds 3 and 1 (each within the scatter of the next); then compounds 4 and 2 (each within the scatter of the next).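

In this assay the place of the bromine on the phenyl ring matters on its own: the two compounds hold the same atoms, yet the step is beyond the scatter (a 4.7-fold higher number from compound 3 to compound 4 (0.67 log units; beyond the scatter)). The 4-bromophenyl compound also stands apart from the 3-chlorophenyl compound (a 2.8-fold higher number from compound 1 to compound 4 (0.45 log units; beyond the scatter)) but not from the 4-methoxyphenyl compound (a 1.8-fold lower number from compound 2 to compound 4 (0.25 log units; within the scatter)), so across these four compounds the numbers split by the place of the substituent more than by its identity, and none goes against this. Nothing available explains this dependence on place.

Still open, going by these compounds, is whether the split holds beyond halogens and methoxy, for instance for a phenyl ring carrying an amine or a carboxylic acid. An unsubstituted phenyl ring would show what either substituent adds.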